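The source may report more compounds than this note shows. Statements on the series, on what has been measured and on what is new or still open speak of the compounds shown alone.

Compound 2 `COc1cccc(Nc2nc3nonc3nc2Nc2ccccc2F)c1` stands with the highest number of the two measured in an assay on mitochondria from L6 cells (Rattus norvegicus) for activation, with a stated time of 90 min (a higher number here means that more compound is needed for the effect, a lower number that less compound is needed), where compound 2 gives 830 nM. Within the data shown here, compound 1 `Fc1cccc(Nc2nc3nonc3nc2Nc2ccccc2F)c1` gives 190 nM in this assay, and the single measured step, a 4.4-fold higher number from compound 1 to compound 2 (0.64 log units; beyond the scatter), goes toward more compound being needed. Compound 3 `Fc1ccccc1Nc1nc2nonc2nc1Nc1cccc(OC(F)(F)F)c1` differs from compound 2 by trifluoromethyl in place of methyl on an oxygen on an aromatic ring. Among the measured compounds shown here, no measured step bears on this change directly: the only step in this assay concerns methoxy in place of fluoro, a modest step, and it gives no direct guide for trifluoromethyl entering on the oxygen. The step from compound 2 to compound 3 in this assay is therefore expected to be small, a 1.4-fold lower number from compound 2 to compound 3 (0.14 log units; within the scatter), with either direction open. For compound 3 the estimate in this assay is 600 nM, with a range from 200 nM to 2500 nM.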

Compound 3, half-maximal effective concentration: 600 nM
Estimate against measurement, compound 3: no gap at the digits printed, within the range that was stated.
By their numbers in this assay, from the lowest: compound 1; then compounds 3 and 2 (each within the scatter of the next).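

In this assay, trifluoromethyl in place of methyl on the oxygen does not separate the two ethers on this aromatic ring (a 1.4-fold lower number from compound 2 to compound 3 (0.14 log units; within the scatter)). Trifluoromethoxy in place of fluoro gives a step beyond the scatter (a 3.2-fold higher number from compound 1 to compound 3 (0.50 log units; beyond the scatter)), so both oxygen-linked groups now stand apart from fluoro, and compound 1 has the lowest number of the three. Nothing available explains either step.

Open, from the compounds shown here alone, is whether a group with no oxygen link, such as an amine, a carboxylic acid or a longer alkyl chain, would fall nearer compound 1 or nearer the two ethers. Also open, going by these compounds, is whether the gap between fluoro and the two ethers holds on any other core.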